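This account rests on a few compounds, and the source may have more. Where it says the series, first, only, none or still open, it means among the compounds named here.

Compound 1 `CC(C(=O)NCc1ccc(C(C)(C)C)nc1OC1CCCCC1)c1ccc(NS(C)(=O)=O)c(F)c1` — 2.5 nM
Compound 2 `CC(C(=O)NCc1ccc(C(C)(C)C)nc1SC1CCCC1)c1ccc(NS(C)(=O)=O)c(F)c1` — 2.5 nM
Compound 3 `CC(C(=O)NCc1ccc(C(C)(C)C)cc1N1CCCCC1)c1ccc(NS(C)(=O)=O)c(F)c1` — 1.9 nM

In an assay on cells for antagonist activity at transient receptor potential cation channel subfamily V member 1 (Homo sapiens), read by FLIPR and calcium flux, with a stated time of 6 min (a higher number here means a weaker inhibitor, a lower number a stronger inhibitor), compound 3 gives 1.9 nM. Compound 1 gives 2.5 nM and compound 2 gives 2.5 nM; both sit within the scatter of compound 3, so the three measured compounds are not separated by this assay.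

Compound 4 `CC(C(=O)NCc1ccc(C(C)(C)C)cc1OC1CCCC1)c1ccc(NS(C)(=O)=O)c(F)c1` is not yet measured. It differs from compound 3 in one place: cyclopentyloxy in place of piperidin-1-yl on an aromatic carbon.

Among the compounds with values here, only one measured step exists, no change at the digits printed from compound 1 to compound 2 (within the scatter), and it exchanges one ring substituent for another at the same kind of position without moving the number. Within the data shown here, no step tests the exact change from compound 3 to compound 4, but the data so far show this position tolerating ring substituents of similar size. Compound 4 is therefore expected to stay close to compound 3, with an estimated step of a 1.3-fold higher number from compound 3 to compound 4 (0.12 log units; within the scatter), giving an expected 2.5 nM with a range of 1 nM to 6 nM.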

Compound 4, inhibition constant: 1.8 nM
The estimate for compound 4 lay 1.4-fold (0.14 log units) above the measured number; the measured number falls inside the stated range.
By their numbers in this assay, from the lowest: compounds 4, 3, 1 and 2 (each within the scatter of the next).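

In this assay, cyclopentyloxy in place of piperidin-1-yl on the aromatic carbon ortho to a large group gives a 1.1-fold lower number from compound 3 to compound 4 (0.02 log units; within the scatter) and so extends the tolerated groups at this position. A five-membered carbon ring attached through oxygen and a six-membered ring attached through nitrogen are not told apart here. No available evidence explains this tolerance.

All four compounds remain within the scatter of the next, so no limit at this position is visible. As far as these compounds go, whether a primary amine, a carboxylic acid or a longer straight alkyl chain would keep the number in this range remains open.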